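Methoxy to Methyl in an Antiproliferative Series

The source may report more compounds than this note shows. Statements on the series, on what has been measured and on what is new or still open speak of the compounds shown alone.

Compound 1 `COc1ccc(N2C(=O)COc3ccc(-c4cnc(Cl)c(NS(=O)(=O)c5ccc(F)cc5)c4)cc32)cc1`: 30100 nM
Compound 2 `COc1cccc(N2C(=O)COc3ccc(-c4cccc(NS(=O)(=O)c5ccc(F)cc5)c4)cc32)c1`: > 40000 nM (a limit, not a number)
Compound 3 `COc1ncc(-c2ccc3c(c2)N(C2CC2)C(=O)CO3)cc1NS(=O)(=O)c1ccc(F)cc1`: 24300 nM

In a functional assay on HCT-116 cells (Homo sapiens) for antiproliferative activity, read by MTT assay, with a stated time of 72 h (on this read-out higher numbers stand for weaker inhibition and lower numbers for stronger inhibition), compound 1 gives 30100 nM. Among the measured compounds shown here, compound 3, at 24300 nM, lies within the usual scatter of compound 1, and these are the only two exact numbers in the set. Compound 2 reads > 40000 nM, which is a limit of the assay.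

Compound 4 `Cc1ccc(N2C(=O)COc3ccc(-c4cnc(Cl)c(NS(=O)(=O)c5ccc(F)cc5)c4)cc32)cc1` keeps the core of compound 1 but carries methyl in place of methoxy on an aromatic carbon, para to a large group, turning 4-methoxyphenyl into 4-methylphenyl (methyl in place of methoxy on an aromatic carbon). For the measured compounds named here, no measured pair here differs in one place alone, so the data offer no direct measure of this change. Starting from compound 1 at 30100 nM, no step beyond the scatter is expected in this assay, in either direction. The estimated step of a 1.2-fold lower number from compound 1 to compound 4 (0.08 log units; within the scatter) stays within that scatter. For compound 4 the expected value is 25000 nM, with an estimated range of 11000 nM to 40000 nM.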

Compound 4, half-maximal inhibitory concentration: 34300 nM
Compound 4: the middle estimate sits 1.4-fold (0.14 log units) below what was measured; measured number inside the range.
By their numbers in this assay, from the lowest: compounds 3, 1 and 4 (each within the scatter of the next). At a limit, above all of these: compound 2.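

The set now holds its first pair differing in one place alone, and in this assay methyl in place of methoxy on an aromatic carbon, para to a large group, gives a 1.1-fold higher number from compound 1 to compound 4 (0.06 log units; within the scatter). Among the compounds shown here, at this position on this core, turning 4-methoxyphenyl into 4-methylphenyl therefore leaves the read-out within the scatter, a direct reading that the earlier compounds could not give. Compound 2 stands at a limit of the assay and not at a number: the limit of > 40000 nM in this assay, at which 1 of the 4 values shown sits.

From the compounds shown here alone, whether this position accepts other groups remains open, since an amine, a carboxylic acid or a longer chain such as ethoxy could still give a different result. Going by these compounds, it is also open whether methyl in place of methoxy would read the same way on another core.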